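This account rests on a few compounds, and the source may have more. Where it says the series, first, only, none or still open, it means among the compounds named here.

Of the compounds shown here, three built on one shared core have been measured in an ADME assay on microsomes from liver (Homo sapiens) for metabolic stability, read by LC-MS, with NADPH named in the record, with a stated time of 60 min, tested at 1 uM, in the absence of a further agent (on this read-out lower numbers stand for a less stable compound and higher numbers for a more stable compound), and all three stand at the same edge of the read-out. Compound 1 `COc1ccc(-c2c(C)sc3c(N4CC[C@@H](NC(C)=O)C4)nc(C)nc23)cc1OC` reaches a limit of the assay, and in this assay compound 1 gives > 95%. Compound 2 `CC(=O)N[C@@H]1CCN(c2cc(C)nn3c(-c4ccc(OC(F)(F)F)cc4)c(C)nc23)C1` likewise reaches a limit, and in this assay compound 2 gives > 95%. Compound 3 `COc1ccc(-c2c(C)nc3c(N4CC[C@@H](NC(=O)NC(C)C)C4)cc(C)nn23)cc1OC`, the starting point of the step followed here, also reaches a limit, and in this assay compound 3 gives > 95%. Where compound 3 stands is therefore told only as a limit, which it shares with the other two: the limit of > 95% in this assay, at which 3 of the 3 values shown sit.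

Compound 4 `COc1ccc(-c2c(C)nc3c(N4CC[C@@H](NS(=O)(=O)c5ccc(C)cc5)C4)cc(C)nn23)cc1OC` differs from compound 3 in a single place, on the amine nitrogen attached to the saturated ring carbon, as follows: (4-methylphenyl)sulfonyl in place of isopropylcarbamoyl on an amine nitrogen. Going by the values given here, no step between measured compounds of this set is available, so nothing in the data shows how far such a change moves the read-out. Because every shown value sits at the limit of > 95% in this assay, at which 3 of the 3 values shown sit, the most that can be said is that compound 3 is at or above the top of the measurable range. Compound 4 is expected to stay high, with a step from compound 3 that is estimated as none beyond the scatter or a slight fall, a number at least 7 percentage points lower from compound 3 to compound 4 (that floor lies within the scatter). For compound 4 the estimated value in this assay is 88%, within a range from 65% to 95%.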

Compound 4, percent of the compound remaining: > 95%
Compound 4 gave a limit, no number; the forecaster's own chance of this, stated with the estimate: 50%; middle value at least 7 percentage points from the limit.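

In this assay compound 4 gives > 95%, which is a limit of the assay and not a number. Compound 3 also stands at a limit, so no step can be read between compound 3 and compound 4. The compounds shown leave open how their stability would differ, because all of them share one edge of the read-out: the limit of > 95% in this assay, at which 4 of the 4 values shown sit.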